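The source may hold more compounds than are shown below. What is called first, only, known or untested is meant among the compounds shown, and "the series" means these compounds.

Measured so far:
compound 1, `Cc1ccccc1C(=O)N[C@@H](C(=O)N1CCC(c2ccc(Cl)cc2)CC1)C(C)C`: 32 nM
compound 2, `CC(C)C(NC(=O)OCc1ccccc1)C(=O)N1CCC(c2ccc(Cl)cc2)CC1`: 1080 nM

Both compounds were run in an assay on THP-1 cells for displacement of a labelled ligand from C-C chemokine receptor type 1 (Homo sapiens); on this read-out lower numbers stand for stronger inhibition and higher numbers for weaker inhibition. Compound 1 gives 32 nM and stands at the lowest number of the two. Compound 2 gives 1080 nM, a number well above that of compound 1, a gap beyond the usual scatter. Within the data shown here, no single-point step between measured compounds is available, so the next change has to be judged from the two values alone.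

The next compound in the series is compound 3, `CC(C)[C@@H](NC(=O)CC1CC1)C(=O)N1CCC(c2ccc(Cl)cc2)CC1`, which is yet to be measured in this assay. Against compound 1 the change is cyclopropylmethyl in place of 2-methylphenyl on a carbonyl carbon. An aromatic six-membered ring is exchanged for a small non-aromatic three-membered ring carrying one methylene; the amide link and the shared core are unchanged. Nothing in the measured pair speaks directly to this exchange.

The expected step of a 7.8-fold higher number from compound 1 to compound 3 (0.89 log units; beyond the scatter) is a rise in the number, beyond the scatter but short of the gap seen for compound 2. Compound 3 is accordingly estimated at 250 nM, with a range from 60 nM to 1200 nM.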

Compound 3, half-maximal inhibitory concentration: 46 nM
Compound 3: middle estimate off by 5.4-fold (0.74 log units), on the high side; the measured number lies below the stated range.
By their numbers in this assay, from the lowest: compounds 1 and 3 (each within the scatter of the next); then compound 2.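

In this assay, cyclopropylmethyl in place of 2-methylphenyl on a carbonyl carbon whose other neighbours are amide-type nitrogen gives a 1.4-fold higher number from compound 1 to compound 3 (0.16 log units; within the scatter), so the two numbers cannot be told apart. For this pair, the aromatic six-membered ring is therefore not required at this position: a three-membered non-aromatic ring of carbon only, with 4 heavy atoms in place of 7, gives a number within the scatter of the original, and neither group carries a hydrogen-bond donor, a hydrogen-bond acceptor or a net charge. There is no supporting data here that would account for this match between the two groups.

This rests on a single pair, so it sets no rule for other groups on this carbonyl carbon or for the same exchange on a different core. Still open, from the compounds shown here alone, is whether the number stays in this range with a group of another kind at this position, such as an amine, a carboxylic acid, a longer chain such as n-butyl, or an unsubstituted phenyl ring.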